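Methoxy to Bromo: Expected Cytotoxicity of Compound 3

A few compounds are considered here, and "the series" means these few. Any claim that something is new, unique, unknown or untested is made for them only; others in the source may bear on it.

Measured so far in a functional assay on IMR-32 cells (Homo sapiens) for cytotoxicity, read by sulforhodamine B assay, with a stated time of 48 h; on this read-out higher numbers stand for weaker inhibition and lower numbers for stronger inhibition:
Compound 1, `CC1=C(/C=C/C(=O)/C=C/c2ccc(Cl)cc2)C(C)(C)CCC1`, gives 52300 nM.
Compound 2, `COc1ccccc1/C=C/C(=O)/C=C/C1=C(C)CCCC1(C)C`, gives 19200 nM.

Compound 2 stands lowest of the two numbers in this assay, and the gap to compound 1 lies beyond the usual scatter of this kind of measurement, so compound 2 is the stronger of the two measured compounds. Among the compounds with values here, the two differ in more than one place, so no single step between them can be read off.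

Compound 3, `CC1=C(/C=C/C(=O)/C=C/c2ccccc2Br)C(C)(C)CCC1`, has not yet been measured. It differs from compound 2 in one place: bromo in place of methoxy on an aromatic carbon. Within the data shown here, no pair of measured compounds isolates this change, so its size cannot be taken from the data. A halogen replacing a small ether group at the same aromatic position is, in the absence of any comparison, expected to move the number only modestly, most likely within the scatter or slightly toward a weaker result.

Compound 3 is therefore expected to give about 25000 nM in this assay, with a range of 10000 nM to 60000 nM, which means an estimated step of a 1.3-fold higher number from compound 2 to compound 3 (0.11 log units; within the scatter).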

Compound 3, half-maximal inhibitory concentration: 16300 nM
Compound 3: middle estimate off by 1.5-fold (0.19 log units), on the high side; the measured number falls inside the stated range.
By their numbers in this assay, from the lowest: compounds 3 and 2 (each within the scatter of the next); then compound 1.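

In this assay, putting bromo in place of methoxy on this aromatic carbon, ortho to a large group, gives a 1.2-fold lower number from compound 2 to compound 3 (0.07 log units; within the scatter) and so leaves the number within the scatter, even though the entering group has one heavy atom where the leaving group has two, and no hydrogen-bond acceptor where the leaving group has one. Going from 4-chlorophenyl to 2-bromophenyl gives a 3.2-fold lower number from compound 1 to compound 3 (0.51 log units; beyond the scatter), a modest step but one beyond the scatter; since the halogen and its place on the ring both differ in this step, the data cannot assign the shift to either one alone. Nothing available here explains either result.

Methoxy and bromo are the only two groups shown on this aromatic carbon, so a single pair cannot show how much this position tolerates in general. As far as these compounds go, whether an amine, a carboxylic acid or a longer chain here would also stay within the scatter of compound 2, or would move the number clearly in either direction, remains open.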